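The source may report more compounds than this note shows. Statements on the series, on what has been measured and on what is new or still open speak of the compounds shown alone.

Compound 1 `COC1=CC(c2cc3cc(Br)ccc3[nH]2)=N/C1=C\c1ccc[nH]1` — in a functional assay on PLC5 cells (Homo sapiens) for cytotoxicity, read by MTT assay (a lower number here means a stronger inhibitor, a higher number a weaker inhibitor), compound 1 gives 6300 nM.
Compound 2 `COC1=CC(c2cc3ccccc3[nH]2)=N/C1=C\c1ccc[nH]1` — in this assay compound 2 gives 13200 nM.

Among these two measurements compound 2 stands at the higher number, with compound 1 as its only neighbour: the step of a 2.1-fold higher number from compound 1 to compound 2 (0.32 log units; beyond the scatter) is modest but beyond the scatter. Compound 3 `COC1=CC(c2cc3ccccc3n2C(=O)OC(C)(C)C)=N/C1=C\c1ccc[nH]1` differs from compound 2 by tert-butoxycarbonyl in place of hydrogen on an aromatic nitrogen. For the measured compounds named here, no measured step touches the aromatic nitrogen of the shared core; the one known step, a 2.1-fold higher number from compound 1 to compound 2 (0.32 log units; beyond the scatter), concerns a different position and so offers no direct guide. With nothing in the data to anchor a direction, compound 3 is expected to land somewhat higher than compound 2 in this assay, an estimated step of a 1.9-fold higher number from compound 2 to compound 3 (0.28 log units; within the scatter), carrying wide uncertainty. The estimated value for compound 3 in this assay is 25000 nM, within a range of 8000 nM to 80000 nM.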

Compound 3, half-maximal inhibitory concentration: > 40000 nM
Compound 3: a limit, no number (the forecaster's own chance of this, stated with the estimate: 20%); middle value at least 1.6-fold (0.20 log units) from the limit.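

The earlier step, a 2.1-fold higher number from compound 1 to compound 2 (0.32 log units; beyond the scatter), lay on an aromatic carbon, whereas this change is the first shown on the aromatic nitrogen of the shared core. Placing tert-butoxycarbonyl there in place of hydrogen gives an at least 3.0-fold higher number from compound 2 to compound 3 (0.48 log units; beyond the scatter), so compound 3 is a weaker inhibitor than compound 2, and this position does respond to substitution in this assay. The reading for compound 3 is a limit and not a number, so the full size of the step stays unknown: the limit of > 40000 nM in this assay, at which 1 of the 3 values shown sits.

With only this one group on that nitrogen, the compounds shown cannot tell whether the step follows from the hydrogen that leaves or from the group that enters. From the compounds shown here alone, how a methyl or an acetyl on the same nitrogen would read in this assay remains open.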